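This account rests on a few compounds, and the source may have more. Where it says the series, first, only, none or still open, it means among the compounds named here.

Compounds measured so far:
compound 1 `COc1ccc(-c2cc(/C=C/C(=O)c3ccc(N)cc3)[nH]n2)cc1`: -63%
compound 2 `COc1cc(-c2cc(/C=C/C(=O)c3ccc(Cl)c(Cl)c3)[nH]n2)cc(OC)c1OC`: -71%

In a functional assay on RXF 393 cells (Homo sapiens) for cytotoxicity, read by sulforhodamine B assay, with a stated time of 48 h, tested at 100 uM (a higher number here means a weaker effect of the compound at the concentration tested, a lower number a stronger effect), compound 2 gives -71%, the lowest of the two numbers shown, though compound 1 with -63% lies within the usual scatter of it, so the two cannot be ranked. Compound 3 `COc1cc(-c2cc(/C=C/C(=O)c3ccc(F)c(F)c3)[nH]n2)cc(OC)c1OC` differs from compound 2 in one place: 3,4-difluorophenyl in place of 3,4-dichlorophenyl on a carbonyl carbon. Within the data shown here, no step between measured compounds is available to size such a change, so the expected step of a number 16 percentage points higher from compound 2 to compound 3 (beyond the scatter) is a modest move toward a higher number, close to the scatter. Compound 3 is expected to give -55%, with a range from -85% to -20%.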

Compound 3, a percentage reported as activity, at one concentration (the size of the read-out at that concentration, not a potency): -61%
Estimate against measurement, compound 3: 6 percentage points above, and the stated range covers the measured number.
By their numbers in this assay, from the lowest: compounds 2, 1 and 3 (each within the scatter of the next).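

In this assay, among these compounds, the exchange of 3,4-dichlorophenyl for 3,4-difluorophenyl on a carbonyl carbon gives a number 10 percentage points higher from compound 2 to compound 3 (within the scatter), the first step that isolates this position. This single step does not separate the two dihalogenated rings, so the exchange of chlorine for fluorine leaves no readable mark on the result. No measured evidence bears on what lies behind this result. Still open, as far as these compounds go, is how this position responds to a phenyl ring without halogen, or to one carrying a carboxylic acid or a dimethylamino group.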